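Three Aryl Substituents on One Core, a Fourth to Come

A few compounds are considered here, and "the series" means these few. Any claim that something is new, unique, unknown or untested is made for them only; others in the source may bear on it.

Compound 1, `Cc1cccc(CN2CC=C(CCC(=O)NO)C2=O)c1`, gives 4280 nM in a functional assay on NUGC-3 cells (Homo sapiens) for inhibition, read by sulforhodamine B assay; a higher number here means a weaker inhibitor of growth, a lower number a stronger inhibitor of growth.
Compound 2, `O=C(CCC1=CCN(Cc2cccc(Br)c2)C1=O)NO`, gives 4280 nM in this assay.
Compound 3, `O=C(CCC1=CCN(Cc2cccc(Cl)c2)C1=O)NO`, gives 4280 nM in this assay.

Compound 3 stands level with compounds 1 and 2 in this assay: the step of no change at the digits printed from compound 1 to compound 3 (within the scatter) and the step of no change at the digits printed from compound 2 to compound 3 (within the scatter) both show no change beyond the scatter, as does the step of no change at the digits printed from compound 1 to compound 2 (within the scatter). The unmeasured compound 4, `N#Cc1cccc(CN2CC=C(CCC(=O)NO)C2=O)c1`, differs from compound 3 as follows: cyano in place of chloro on an aromatic carbon.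

Going by the values given here, no measured step involves a cyano group, so nothing directly bears on this change. What the three measured steps do show is that swapping methyl, bromo and chloro at this aromatic carbon left this assay untouched within the scatter. On that basis the expectation for compound 4 is a step of about a 1.0-fold higher number from compound 3 to compound 4 (0.00 log units; within the scatter), that is, none beyond the scatter. Compound 4 is therefore estimated at 4300 nM, with a range from 1800 nM to 10000 nM.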

Compound 4, concentration for 50% growth inhibition: 4120 nM
Compound 4: the middle estimate sits 1.0-fold (0.02 log units) above what was measured; the range from low to high includes it.
By their numbers in this assay, from the lowest: compounds 4, 1, 2 and 3 (each within the scatter of the next).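

In this assay, cyano in place of chloro gives a 1.0-fold lower number from compound 3 to compound 4 (0.02 log units; within the scatter), cyano in place of bromo gives a 1.0-fold lower number from compound 2 to compound 4 (0.02 log units; within the scatter), and cyano in place of methyl gives a 1.0-fold lower number from compound 1 to compound 4 (0.02 log units; within the scatter). The insensitivity seen among methyl, bromo and chloro on this aromatic carbon, meta to a large group, therefore also covers cyano, which has two heavy atoms, a triple bond and a hydrogen-bond acceptor, where the chloro it replaces has one heavy atom and no acceptor. No measurement is available to explain why these exchanges leave the number in place.

The compounds shown leave open whether an amine, a carboxylic acid or a longer chain on this carbon would also leave the number in place. They also leave open whether any of these groups would do the same on another carbon of the six-membered aromatic ring.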